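This account rests on a few compounds, and the source may have more. Where it says the series, first, only, none or still open, it means among the compounds named here.

Measured so far:

Compound 1 `CC(C(=O)NCc1ccc(C(F)(F)F)nc1N1CC=CCC1)c1ccc(NS(C)(=O)=O)c(F)c1` — in a functional assay on CHO-K1 cells for antagonist activity at transient receptor potential cation channel subfamily V member 1 (Homo sapiens), read by FLIPR (on this read-out lower numbers stand for stronger inhibition and higher numbers for weaker inhibition), compound 1 gives 12.1 nM.
Compound 2 `CC(C(=O)NCc1ccc(C(F)(F)F)nc1N1CCC(C(=O)c2ccc(F)cc2)CC1)c1ccc(NS(C)(=O)=O)c(F)c1` — in this assay compound 2 gives 990 nM.

Two compounds share the core and differ in the ring attached to the pyridine nitrogen of the shared core. Compound 2 stands at the highest of the two numbers, and the gap from compound 1 to compound 2 lies well beyond the scatter: the ring carrying the large (4-fluorophenyl)carbonyl group goes with a much weaker result than the unsubstituted unsaturated ring of compound 1.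

Compound 3 `COC1CCN(c2nc(C(F)(F)F)ccc2CNC(=O)C(C)c2ccc(NS(C)(=O)=O)c(F)c2)CC1` is next for this assay. It keeps the saturated ring of compound 2 but replaces the large group on it: methoxy in place of (4-fluorophenyl)carbonyl on a saturated ring carbon. Within the data shown here, no measured pair shows this exact change, so the expectation rests on the two values. Since the weak result of compound 2 at 990 nM coincides with the only large substituent on that ring, removing most of it is expected to move the number back toward compound 1, although not necessarily all the way.

The step from compound 2 to compound 3 is therefore expected to be a clear drop, a 22-fold lower number from compound 2 to compound 3 (1.34 log units; beyond the scatter). Compound 3 is estimated at 45 nM, with a range from 10 nM to 250 nM.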

Compound 3, half-maximal inhibitory concentration: 280 nM
For compound 3 the middle estimate is 6.2-fold (0.79 log units) below the measured one, and the stated range ends below it.
By their numbers in this assay, from the lowest: compound 1; then compound 3; then compound 2.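

Working notes on the ring attached to the pyridine nitrogen: in this assay, methoxy in place of (4-fluorophenyl)carbonyl on the saturated ring carbon, three ring bonds from the ring nitrogen, gives a 3.5-fold lower number from compound 2 to compound 3 (0.55 log units; beyond the scatter), so this change recovers only a modest part of the gap to the best number in the set. Even with only methoxy on the saturated ring, the result remains far from that of the unsubstituted unsaturated ring, with a 23-fold higher number from compound 1 to compound 3 (1.36 log units; beyond the scatter), which shows that the large (4-fluorophenyl)carbonyl group does not account for the whole gap between compound 1 and compound 2. No measurement at hand bears on the reason for either step.

Still open, as far as these compounds go, is how much of the remaining gap belongs to methoxy and how much to the change of ring, since compound 1 and compound 3 differ in both the substituent and the ring. A saturated ring with no substituent would separate these two parts, and a hydroxy group or a methyl group on the same ring carbon would show whether the oxygen of methoxy matters there.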